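This account rests on a few compounds, and the source may have more. Where it says the series, first, only, none or still open, it means among the compounds named here.

Compound 1 `N[C@H]1CC[C@H](Nc2c(C(=O)NCc3ccco3)nc(Br)c3cccnc23)CC1` is the starting point of this account. In a functional assay on MCF7 cells (Homo sapiens) for cytotoxicity, read by MTT assay, with a stated time of 72 h (on this read-out lower numbers stand for stronger inhibition and higher numbers for weaker inhibition), compound 1 is recorded as "not determined" (no result reported), so it has no single number of its own. Among the compounds with values here, the only other values shown for this series are limits rather than numbers. Compound 2 `CC(C)(C)OC(=O)N1CCN(c2c(C(=O)NCc3ccc(F)cc3)nc(Br)c3cccnc23)CC1` carries a different amine on the shared core, and in this assay compound 2 gives > 10000 nM, which is a limit of the assay. Compound 3 `CNCCCNc1c(C(=O)NCc2ccc(F)cc2)nc(Br)c2cccnc12` carries an open-chain amine there, and in this assay compound 3 gives > 10000 nM, again a limit. Within the data shown here, both of these sit at the limit of > 10000 nM in this assay, at which 2 of the 3 values shown sit, so nothing in the measured set pins compound 1 to a particular point, and no step between measured compounds is available.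

The compound that follows is compound 4 `N[C@H]1CC[C@H](Nc2c(C(=O)NC3CCCCC3)nc(Br)c3cccnc23)CC1`. It differs from compound 1 in one place: cyclohexyl in place of (furan-2-yl)methyl on an amide-type nitrogen. Among the measured compounds shown here, no measured pair shows what this change does in this assay, so no step can be stated; the expectation is that, with two of three values at the limit, the step from compound 1 will fall within the scatter or leave compound 4 near that same limit. On that basis compound 4 is estimated at 10000 nM in this assay, expected to lie between 2000 nM and 40000 nM.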

Compound 4, half-maximal inhibitory concentration: 5200 nM
Estimate against measurement, compound 4: 1.9-fold (0.28 log units) above, and the stated range covers the measured number.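

No step can be read from compound 1 to compound 4: in this assay compound 1 stands as "not determined" (no result reported), whereas compound 4 gives 5200 nM. The compounds shown leave open what cyclohexyl in place of (furan-2-yl)methyl on the amide-type nitrogen does in this assay.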